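A few compounds are considered here, and "the series" means these few. Any claim that something is new, unique, unknown or untested is made for them only; others in the source may bear on it.

In an ADME assay on microsomes from liver (Rattus norvegicus) for metabolic stability, read by LC-MS, using NADPH, at 37 degrees C (a lower number here means that the compound disappears faster, a higher number that the compound lasts longer), compound 1 `Cc1ccccc1-c1nc(CN2CCC(C(=O)NCCCN3[C@H](C)CCC[C@@H]3C)CC2)c(C)o1` gives > 0.5 h, which is a limit of the assay and not a number. Going by the values given here, compound 2 `Cc1ccccc1-c1nc(CN2CCC(C(=O)NCCCN3CCCC(CC(C)C)C3)CC2)c(C)o1` gives 0.0383 h, the only actual number so far. Among the compounds with values here, the one measured step, an at least 13-fold lower number from compound 1 to compound 2 (1.11 log units; beyond the scatter), is large and lies at the same place as the next change. Compound 3 `Cc1ccccc1-c1nc(CN2CCC(C(=O)NCCCCN3C[C@H](C)C[C@H](C)C3)CC2)c(C)o1` carries a group of 9 heavy atoms (8 carbon, 1 nitrogen; one six-membered non-aromatic ring with 1 hetero atom) in place of a group of 10 heavy atoms (9 carbon, 1 nitrogen; one six-membered non-aromatic ring with 1 hetero atom), on a saturated chain carbon, three bonds along the chain from an amide-type nitrogen, with (3,5-dimethylpiperidin-1-yl)methyl as the entering group. That single step shows this place can matter, but it does not fix a direction here, so only a small rise is expected. The expected change is a 1.6-fold higher number from compound 2 to compound 3 (0.19 log units; within the scatter). For compound 3 the estimate is 0.06 h, within an expected range from 0.02 h to 0.2 h.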

Compound 3, half-life: 0.2 h
The estimate for compound 3 lay 3.3-fold (0.52 log units) below the measured number; measured number inside the range.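

In this assay, the place on a saturated chain carbon, three bonds along the chain from an amide-type nitrogen, now shows a second clear change: a 5.2-fold higher number from compound 2 to compound 3 (0.72 log units; beyond the scatter), with (3,5-dimethylpiperidin-1-yl)methyl entering. Against the 2,6-dimethylpiperidin-1-yl group the same entering group gives an at least 2.5-fold lower number from compound 1 to compound 3 (0.39 log units; beyond the scatter), so the three compounds separate beyond the scatter. The value of compound 1 is a limit and not a number: the limit of > 0.5 h in this assay, at which 1 of the 3 values shown sits.

From the compounds shown here alone, the true size of that last step stays open. So does the half-life with a morpholin-4-yl group or an unsubstituted piperidin-1-yl group at this place.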